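A few compounds are considered here, and "the series" means these few. Any claim that something is new, unique, unknown or untested is made for them only; others in the source may bear on it.

Measured in a physicochemical assay for solubility, read by HPLC, in simulated intestinal fluid, with a stated time of 16 h, tested at 125 ug/mL; on this read-out lower numbers stand for lower solubility and higher numbers for higher solubility:
Compound 1 `CNC(=O)c1cc(C(=O)NC2CCC2)cn(Cc2ccncc2)c1=O` gives 121 ug/mL.
Compound 2 `CNC(=O)c1cc(C(=O)NC2CC2)cn(Cc2cccc3cc[nH]c23)c1=O` gives 11 ug/mL.
Compound 3 `CNC(=O)c1cc(C(=O)NC2CC2)cn([C@H](C)c2ccccc2)c1=O` gives 815 ug/mL.

Among these three, compound 2 stands lowest in this assay; compound 1 sits above it beyond the scatter, and compound 3 lies further above still. Compound 4 `CNC(=O)c1cc(C(=O)NC2CC2)cn(Cc2cccc3[nH]ncc23)c1=O` has not yet been measured. It differs from compound 2 in a single place: 1H-indazol-4-yl in place of 1H-indol-7-yl on a saturated chain carbon bound to an aromatic nitrogen. For the measured compounds named here, no measured pair shows this particular change, so its effect in this assay can only be anticipated. Starting from compound 2 at 11 ug/mL, a modest rise is expected, of a size close to the edge of the scatter. The step from compound 2 to compound 4 is estimated as a 2.3-fold higher number from compound 2 to compound 4 (0.36 log units; beyond the scatter). Compound 4 is expected to give about 25 ug/mL, ranging from 8 ug/mL to 80 ug/mL.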

Compound 4, solubility: 4 ug/mL
The estimate for compound 4 lay 6.3-fold (0.80 log units) above the measured number; measured number below the stated range.
By their numbers in this assay, from the lowest: compound 4; then compound 2; then compound 1; then compound 3.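

Exchanging 1H-indol-7-yl for 1H-indazol-4-yl on a saturated chain carbon bound to an aromatic nitrogen gives a 2.8-fold lower number from compound 2 to compound 4 (0.44 log units; beyond the scatter) in this assay. This shows that the place responds to the exchange, although both groups have the same heavy-atom count and each has a hydrogen-bond donor; the entering group adds a ring nitrogen and a hydrogen-bond acceptor. Nothing available accounts for the direction of this step. The compounds shown leave open how this place would respond to a group bearing an amine or a carboxylic acid.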